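Compound 2 to compound 4: cyclohexyl on the aromatic nitrogen

The source may report more compounds than this note shows. Statements on the series, on what has been measured and on what is new or still open speak of the compounds shown alone.

In an ADME assay on Vero cells (Chlorocebus sabaeus) for cytotoxicity, read by MTT assay, with a stated time of 96 h (a lower number here means that less compound is tolerated, a higher number that more compound is tolerated), compound 1 `C/C(=N\O)c1ccc2[nH]c(-c3ccccc3)nc2c1` gives > 100000 nM, a limit of the assay and not a number. Compound 2 `C/C(=N\NC(N)=O)c1ccc2[nH]c(-c3ccccc3)nc2c1` gives > 100000 nM, again a limit only. Compound 3 `C/C(=N\NC(N)=O)c1ccc2[nH]c(-c3ccc(C(F)(F)F)cc3)nc2c1` gives > 100000 nM, also a limit. Among the measured compounds shown here, the series so far offers only (the limit of > 100000 nM in this assay, at which 3 of the 3 values shown sit), so compound 2 stands without a number of its own.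

Compound 4 `C/C(=N\NC(N)=O)c1ccc2c(c1)nc(-c1ccccc1)n2C1CCCCC1` carries cyclohexyl in place of hydrogen on an aromatic nitrogen, (cyclohexyl in place of hydrogen on an aromatic nitrogen).

Two measured steps start from or lead to compound 2: a step that the two limits leave unreadable from compound 1 to compound 2 and a step that the two limits leave unreadable from compound 2 to compound 3. Neither has a readable size, and neither falls on the aromatic nitrogen, so they set no size for this change.

With compound 2 at > 100000 nM, any readable change is expected to run toward less compound tolerated. A modest step in this assay is therefore expected, though compound 4 may well report the same limit. The estimated change is an at least 1.4-fold lower number from compound 2 to compound 4 (0.15 log units; that floor lies within the scatter). For compound 4 the estimated value is 70000 nM, with an expected range from 20000 nM to 100000 nM.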

Compound 4, half-maximal cytotoxic concentration: > 100000 nM
Compound 4 gave a limit, no number (the forecaster's own chance of this, stated with the estimate: 55%); middle value at least 1.4-fold (0.15 log units) away from the limit.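

In this assay compound 4 gives > 100000 nM, a limit and not a number. Compound 2 also stands at a limit, so the step to compound 4 cannot be read. The compounds shown leave open the size of any effect of these changes in this assay, since they offer only one limit: the limit of > 100000 nM in this assay, at which 4 of the 4 values shown sit.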